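The source may report more compounds than this note shows. Statements on the series, on what has been measured and on what is new or still open speak of the compounds shown alone.

In a functional assay on HCT-116 cells (Homo sapiens) for antiproliferative activity, read by CellTiter-Glo, with a stated time of 72 h (on this read-out higher numbers stand for weaker inhibition and lower numbers for stronger inhibition), compound 3 `O=C(NO)c1ccc(/C=C/c2ccnc(Br)c2)cc1` gives > 10000 nM, which is a limit of the assay and not a number. All that can be said is that compound 3 stands at the limit, with no measured potency to start from. Compound 4 `O=C(NO)c1ccc(/C=C/c2ccnc(-c3ccsc3)c2)cc1` differs from it at one place, with thiophen-3-yl in place of bromo on an aromatic carbon.

Two measured compounds already carry a ring at that place. Compound 1 `O=C(NO)c1ccc(/C=C/c2ccnc(-c3cc(F)ccc3O)c2)cc1`, with 5-fluoro-2-hydroxyphenyl, gives 2040 nM. Compound 2 `O=C(NO)c1ccc(/C=C/c2ccnc(-c3ccccc3O)c2)cc1`, with 2-hydroxyphenyl, gives 1450 nM. These two sit within the scatter of each other, as a 1.4-fold lower number from compound 1 to compound 2 (0.15 log units; within the scatter) shows. Exchanging either ring for bromo costs activity, seen as an at least 4.9-fold higher number from compound 1 to compound 3 (0.69 log units; beyond the scatter) and an at least 6.8-fold higher number from compound 2 to compound 3 (0.83 log units; beyond the scatter). Both sizes are only minimum sizes, since compound 3 has no exact value.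

Compound 4 makes the reverse exchange, so a clear drop in the number is expected, toward stronger inhibition. Thiophen-3-yl is a different ring from both of these, and no measured compound carries it, so the range has to stay wide. The expected size of the change is an at least 5.5-fold lower number from compound 3 to compound 4 (0.74 log units; beyond the scatter). The estimate for compound 4 is 1800 nM, with an expected range from 600 nM to 5500 nM.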

Compound 4, half-maximal inhibitory concentration: 1910 nM
Compound 4: the middle estimate sits 1.1-fold (0.03 log units) below what was measured, within the range that was stated.
By their numbers in this assay, from the lowest: compounds 2, 4 and 1 (each within the scatter of the next). At a limit, above all of these: compound 3.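

In this assay, the gain over bromo at this place, next to the ring nitrogen, does not require a hydroxyphenyl ring: thiophen-3-yl, which carries no hydroxy group, also gives a clear step, an at least 5.2-fold lower number from compound 3 to compound 4 (0.71 log units; beyond the scatter). Set against the two hydroxyphenyl rings, thiophen-3-yl stays within the scatter, with a 1.3-fold higher number from compound 2 to compound 4 (0.12 log units; within the scatter) and a 1.1-fold lower number from compound 1 to compound 4 (0.03 log units; within the scatter), so among these three compounds the hydroxy group and the size of the ring make no difference that can be read. The value of compound 3 is a limit and not a number, so the step from it gives only a minimum size: the limit of > 10000 nM in this assay, at which 1 of the 4 values shown sits.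

Every group shown at this place is either bromo or an aromatic ring, so it remains open what an amine, a carboxylic acid or a longer chain would do here. Going by these compounds, it also remains open whether any other ring at this place could bring the number clearly below the level shared by compounds 1, 2 and 4, which all lie within the scatter of one another.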